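The source may hold more compounds than are shown below. What is called first, only, known or untested is meant among the compounds shown, and "the series" means these compounds.

Compound 3 `COc1ccc(N2CCN(C(=S)SCc3ccc(C(=O)Nc4ccccc4N)cc3)CC2)cc1` carries a 4-methoxyphenyl on an amine nitrogen in a ring. In a functional assay on A-375 cells (Homo sapiens) for antiproliferative activity, read by CCK-8 assay, with a stated time of 72 h, tested at 2 uM (a higher number here means a stronger effect of the compound at the concentration tested, a lower number a weaker effect), compound 3 gives 28.1%, the second highest of the three numbers measured. Compound 1 `Nc1ccccc1NC(=O)c1ccc(CSC(=S)N2CCN(c3ccccc3)CC2)cc1` gives 27.5% in this assay, and the step is a number 0.6 percentage points higher from compound 1 to compound 3 (within the scatter). For the measured compounds named here, compound 2 `Nc1ccccc1NC(=O)c1ccc(CSC(=S)N2CCN(c3cccnc3)CC2)cc1` gives 40.5%; here a number 12.4 percentage points lower from compound 2 to compound 3 (beyond the scatter) and a number 13 percentage points higher from compound 1 to compound 2 (beyond the scatter), the only two steps in the set that exceed the scatter, and both concern exchange of the whole aryl ring on that nitrogen rather than a substituent on it.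

Compound 4 `N#Cc1ccc(N2CCN(C(=S)SCc3ccc(C(=O)Nc4ccccc4N)cc3)CC2)cc1` differs from compound 3 by cyano in place of methoxy on an aromatic carbon. The step that bears on it is that from compound 1 to compound 3, where methoxy in place of hydrogen at the same aromatic carbon gave a number 0.6 percentage points higher from compound 1 to compound 3 (within the scatter). Going by the values given here, no measured step exchanges methoxy for cyano, so the expected change in this assay is none beyond the scatter, with direction undetermined: the step of a number 2.9 percentage points higher from compound 3 to compound 4 (within the scatter) is the estimate. Compound 4 is therefore expected to give about 31%, in the range 17% to 47%.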

Compound 4, a percentage reported as inhibition, at one concentration (the size of the read-out at that concentration, not a potency): 41.4%
The estimate for compound 4 lay 10.4 percentage points below the measured number, within the range that was stated.
By their numbers in this assay, from the lowest: compounds 1 and 3 (each within the scatter of the next); then compounds 2 and 4 (each within the scatter of the next).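

At this position, on an aromatic carbon para to a large group, the choice of substituent does change the read-out in this assay: cyano in place of methoxy gives a number 13.3 percentage points higher from compound 3 to compound 4 (beyond the scatter) and cyano in place of hydrogen gives a number 13.9 percentage points higher from compound 1 to compound 4 (beyond the scatter) while the earlier exchange of hydrogen for methoxy stayed within the scatter. For the compounds shown here, the higher level seen with the pyridin-3-yl ring is therefore also reached with a substituted phenyl ring, as 4-cyanophenyl in place of pyridin-3-yl gives a number 0.9 percentage points higher from compound 2 to compound 4 (within the scatter) and the earlier steps beyond the scatter no longer all rest on a change of ring type. No measured property is available to explain the step to cyano.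

As far as these compounds go, whether the rise is particular to the nitrile or also appears with a carboxylic acid, an amine or trifluoromethyl on the same carbon remains open. Also open, from the compounds shown here alone, is whether a nitrile on the pyridin-3-yl ring of compound 2 would raise the number further.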